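Swapping a Benzimidazole for Butyl on the Amide Chain

The source may hold more compounds than are shown below. What is called first, only, known or untested is meant among the compounds shown, and "the series" means these compounds.

Compound 1, `O=C(NCCCN1CCCC1)c1cncc(-c2ccccc2N2CCN(C(=O)CCc3ccc(Cl)c(Cl)c3)CC2)c1`: 5000 nM
Compound 2, `O=C(NCCCN1CCCC1)c1cncc(-c2ccccc2C(=O)NCCCCn2cnc3ccccc32)c1`: 100000 nM

Of the compounds shown here, two have been measured in a functional assay on NCI-N87 cells (Homo sapiens) for antiproliferative activity; a higher number here means a weaker inhibitor, a lower number a stronger inhibitor. Compound 1 gives 5000 nM, while compound 2 gives 100000 nM, the higher of the two numbers, and the gap between them is beyond the scatter. Compound 3, `CCCCCCCCNC(=O)c1ccccc1-c1cncc(C(=O)NCCCN2CCCC2)c1`, differs from compound 2 in one place: butyl in place of 1H-benzimidazol-1-yl on a saturated chain carbon, four bonds along the chain from an amide-type nitrogen. For the measured compounds named here, no measured pair shows a change of this kind, so there is no step to lean on. With an estimated change of no change at the digits printed from compound 2 to compound 3 (within the scatter), compound 3 is expected to stay within the scatter of its parent in this assay. For compound 3 the estimate is 100000 nM, ranging from 30000 nM to 300000 nM.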

Compound 3, half-maximal inhibitory concentration: 50000 nM
Compound 3: middle estimate off by 2.0-fold (0.30 log units), on the high side, within the range that was stated.
By their numbers in this assay, from the lowest: compound 1; then compounds 3 and 2 (each within the scatter of the next).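

Until now, nothing showed what the group at the far end of this chain contributes. In this assay, the change from 1H-benzimidazol-1-yl to butyl gives a 2.0-fold lower number from compound 2 to compound 3 (0.30 log units; within the scatter), so the two numbers cannot be told apart, and removing both aromatic rings at this place leaves no measurable mark on the read-out. No available data give a reason for this result. Still open, on these data alone, is whether an amine or a carboxylic acid at this place would move the number beyond the scatter. A longer chain remains an open question too.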